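A few compounds are considered here, and "the series" means these few. Any claim that something is new, unique, unknown or untested is made for them only; others in the source may bear on it.

Compound 1 `CCOC(=O)/C=C/C=C/c1ccc[nH]1` gives > 10000 nM in a functional assay on Raji cells (Homo sapiens) for cytotoxicity, with a stated time of 72 h; on this read-out higher numbers stand for weaker inhibition and lower numbers for stronger inhibition.
Compound 2 `CCOC(=O)/C=C/C=C/C=C/c1ccc[nH]1` gives > 10000 nM in this assay.
Compound 3 `CCOC(=O)/C=C/C=C/c1[nH]ccc1Cl` gives > 10000 nM in this assay.

Each of these three values is a limit of the assay and not a number. Compound 1 is a starting point; compound 3 differs from it by chloro in place of hydrogen on an aromatic carbon, and the step that the two limits leave unreadable from compound 1 to compound 3 stays unreadable because of the limit of > 10000 nM in this assay, at which 3 of the 3 values shown sit. The cores of compound 1 and compound 2 differ in a way that is not broken down here. Compound 4 `CCOC(=O)/C=C/C=C/C=C/c1[nH]ccc1Cl` has not been measured; it differs from compound 2 by chloro in place of hydrogen on an aromatic carbon. The surroundings of the place differ only in wording, a large group against a group of 9 heavy atoms, so this is the same kind of change as that from compound 1 to compound 3. The step that the limit leaves unreadable from compound 2 to compound 4 is expected to be small, resting on compound 3 and (the limit of > 10000 nM in this assay, at which 3 of the 3 values shown sit). Compound 4 is estimated at 20000 nM, between 5000 nM and 100000 nM.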

Compound 4, half-maximal inhibitory concentration: > 10000 nM
Compound 4 gave a limit, no number; the forecaster's own chance of this, stated with the estimate: 85%; the middle value does not contradict the limit.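

No step can be read from compound 2 to compound 4, as both results are limits and not numbers: the limit of > 10000 nM in this assay, at which 4 of the 4 values shown sit. The compounds shown leave open how strongly any of them acts in this assay, and whether chloro in place of hydrogen changes that.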